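This account rests on a few compounds, and the source may have more. Where it says the series, first, only, none or still open, it means among the compounds named here.

The measured compounds are:
compound 1, `COc1cc(C2OC(c3ccccc3N(C)C)=NN2C(C)=O)cc(OC)c1OC`, which gives 65 uM in a functional assay on HCT-15 cells (Homo sapiens); a higher number here means that more compound is needed for the effect, a lower number that less compound is needed;
compound 2, `COc1cc(C2OC(c3ccc(N(C)C)cc3)=NN2C(C)=O)cc(OC)c1OC(C)=O`, which gives 78 uM in this assay;
compound 3, `COc1cc(C2OC(c3ccc(N(C)C)cc3)=NN2C=O)cc(OC)c1OC`, which gives 0.096 uM in this assay.

Compound 3 stands lowest of the three numbers. Its gaps to compound 1 and to compound 2 both lie beyond the usual scatter, so compound 3 is the most potent of the three. Compound 1 and compound 2 each differ from compound 3 in more than one place, so no single step can be read from them; their values show only that both need far more compound than compound 3.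

Compound 4, `COc1cc(C2OC(c3ccc(N(C)C)cc3)=NN2C(=O)CNC(C)=O)cc(OC)c1OC`, has not yet been measured in this assay. It differs from compound 3 in one place: acetamidomethyl in place of hydrogen on a carbonyl carbon — read one bond further out, formyl becomes (acetamidomethyl)carbonyl. Among the compounds with values here, no measured pair shows this change, so the expectation rests on compound 3 alone, which gives 0.096 uM in this assay. A moderate step toward a higher number is expected, a 10-fold higher number from compound 3 to compound 4 (1.02 log units; beyond the scatter), likely beyond the scatter. Compound 4 is estimated at 1 uM, with a range from 0.15 uM to 8 uM.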

Compound 4, concentration for half-maximal effect: 0.18 uM
Beside the measured number, compound 4's estimate is 5.6-fold (0.74 log units) above it; measured number inside the range.
By their numbers in this assay, from the lowest: compounds 3 and 4 (each within the scatter of the next); then compounds 1 and 2 (each within the scatter of the next).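

In this assay, putting acetamidomethyl in place of hydrogen on the carbonyl carbon, whose other neighbour is the amide-type nitrogen in a ring, gives a 1.9-fold higher number from compound 3 to compound 4 (0.27 log units; within the scatter), so formyl and (acetamidomethyl)carbonyl cannot be told apart at this position. Within the data shown here, compounds 1 and 2 each differ from compound 3 in more than one place and could not show this; compound 4 is the first to show that a chain of this size can stand here with the number staying within the scatter of compound 3. Nothing in the data shown gives a cause for this result.

From the compounds shown here alone, it remains open whether a free amine, a carboxylic acid or a longer chain in place of acetamidomethyl would also stay within the scatter of compound 3. Going by these compounds, it also remains open whether a ring at this carbonyl carbon would do so.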